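This account rests on a few compounds, and the source may have more. Where it says the series, first, only, none or still open, it means among the compounds named here.

Measured compounds:
Compound 1, `CNC1=C(Cl)C(=O)c2cccnc2C1=O`, in a functional assay on cells (Neutrophil, Homo sapiens) for inhibition, read by WST assay, with a stated time of 20 min (a lower number here means a stronger inhibitor, a higher number a weaker inhibitor), gives 41100 nM.
Compound 2, `CS(=O)(=O)C1=C(N)C(=O)c2cccnc2C1=O`, gives in this assay only a limit, > 200000 nM.

Going by the values given here, compound 1 thus holds the only number in this assay; nothing can be ranked against it. Among the compounds with values here, the remaining value is the limit of > 200000 nM in this assay, at which 1 of the 2 values shown sits, a limit and not a number, so no measured step between two compounds of this set exists.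

Compound 3, `CNC1=C(SC)C(=O)c2cccnc2C1=O`, differs from compound 1 by methylsulfanyl in place of chloro on a double-bonded ring carbon of the shared core. Within the data shown here, no measured pair in this set carries a change of this kind, so the size of the step rests on expectation alone. The step from compound 1 to compound 3 is expected to be a 1.2-fold higher number from compound 1 to compound 3 (0.09 log units; within the scatter), a shift that need not lie beyond the usual scatter. Compound 3 is therefore estimated at 50000 nM, with a range from 15000 nM to 150000 nM.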

Compound 3, half-maximal inhibitory concentration: > 200000 nM
Compound 3: a limit, no number (the forecaster's own chance of this, stated with the estimate: 20%); at least 4.0-fold (0.60 log units) between middle value and limit.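

Methylsulfanyl in place of chloro on a double-bonded ring carbon, next to the ring atom that bears a methylamino group, gives the first step that can be read at this position in this assay, an at least 4.8-fold higher number from compound 1 to compound 3 (0.68 log units; beyond the scatter). Compound 3 gives only a limit, > 200000 nM, so the step has a lower bound and no exact size. Chloro in compound 1 remains the only group at this position with a number, and compound 3 joins the values that are limits: the limit of > 200000 nM in this assay, at which 2 of the 3 values shown sit.

From the compounds shown here alone, whether fluoro, methoxy or an amine on this carbon would give a number in this assay stays open. Also open, going by these compounds, is what a longer chain in place of the methylamino group would do with chloro kept in place.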